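From chloro to cyclopropylamino: compound 1 to compound 4

The compounds below may be only part of what the source reports. "The series", "measured", "known", "first", "only" and "open" are said of these compounds alone.

In a functional assay on KB cells (Homo sapiens) for inhibition (on this read-out higher numbers stand for weaker inhibition and lower numbers for stronger inhibition), compound 1 (`Clc1cc2nc(Cl)n(Cc3ccccc3)c2cc1Cl`) gives > 100000 nM, which is a limit of the assay. Compound 2 (`Clc1ccc(Cn2c(Cl)nc3cc(Cl)c(Cl)cc32)cc1`) gives > 100000 nM, also a limit. Compound 3 (`FC(F)(F)c1cccc(Cn2c(Cl)nc3cc(Cl)c(Cl)cc32)c1`) gives > 100000 nM, again a limit. Compound 1 thus has no number, only its place at the limit of > 100000 nM in this assay, at which 3 of the 3 values shown sit.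

Compound 4 (`Clc1cc2nc(NC3CC3)n(Cc3ccccc3)c2cc1Cl`) carries cyclopropylamino in place of chloro on an aromatic carbon of a five-membered aromatic ring with 2 nitrogen: cyclopropylamino in place of chloro on an aromatic carbon.

The measured steps give no size to carry over: a step that the two limits leave unreadable from compound 1 to compound 2 and a step that the two limits leave unreadable from compound 1 to compound 3, both hydrogen replacements elsewhere. The expected step in this assay is an at least 1.6-fold lower number from compound 1 to compound 4 (0.22 log units; that floor lies within the scatter), a modest one towards stronger inhibition, and another limit reading remains quite possible. For compound 4 the estimate is 60000 nM, with an expected range of 15000 nM to 150000 nM.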

Compound 4, half-maximal inhibitory concentration: 60000 nM
Compound 4: middle estimate and measured number agree at the digits printed; the measured number falls inside the stated range.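

On the carbon between two ring nitrogen atoms, cyclopropylamino in place of chloro gives an at least 1.6-fold lower number from compound 1 to compound 4 (0.22 log units; that floor lies within the scatter). In this assay, for the compounds shown here, compound 4 is thus the first with a readable number, whereas the steps among the earlier compounds cannot be read. It stands alone in that respect: the limit of > 100000 nM in this assay, at which 3 of the 4 values shown sit.

Still open, going by these compounds, is whether another amine at this carbon, such as ethylamino or morpholine, reads lower. Also open, on these data alone, is whether the chloro of compound 2 or the trifluoromethyl of compound 3 shifts the reading once cyclopropylamino is present.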